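Dienone series: aryl swap on the benzylidene carbon

The compounds below may be only part of what the source reports. "The series", "measured", "known", "first", "only" and "open" are said of these compounds alone.

Of the compounds shown here, two of the shared core have numbers so far. Compound 1 `C=C(C/C(=C\c1ccccc1)C(=O)c1ccccc1)C(=O)c1ccccc1` gives 3000 nM in a functional assay on SW1573 cells (Homo sapiens) for inhibition, read by sulforhodamine B assay, with a stated time of 48 h; a lower number here means a stronger inhibitor of growth, a higher number a weaker inhibitor of growth. Compound 2 `C=C(C/C(=C\c1ccccc1F)C(=O)c1ccccc1)C(=O)c1ccccc1` gives 3500 nM in this assay. Within the data shown here, the only step between them is a 1.2-fold higher number from compound 1 to compound 2 (0.07 log units; within the scatter), a fluoro in place of hydrogen on an aromatic carbon, and it stays within the scatter. Among the measured compounds shown here, compound 2 therefore stands at a number that cannot be told apart from that of compound 1; there are only two numbers, and they sit together.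

Compound 3 `C=C(C/C(=C\c1ccc(OC)cc1)C(=O)c1ccccc1)C(=O)c1ccccc1` is not yet measured. It differs from compound 2 by 4-methoxyphenyl in place of 2-fluorophenyl on a double-bonded chain carbon bound to a double-bonded chain carbon. For the measured compounds named here, no measured step covers a methoxy group or this aryl swap; the one step that touches the same ring, from compound 1 to compound 2, is small and within the scatter. Going by the values given here, with that as the only guide, no step beyond the scatter is expected in this assay from compound 2 to compound 3, the expected step being no change at the digits printed from compound 2 to compound 3 (within the scatter). Compound 3 is therefore estimated at 3500 nM in this assay, with a range from 1500 nM to 8000 nM.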

Compound 3, concentration for 50% growth inhibition: 450 nM
The estimate for compound 3 lay 7.8-fold (0.89 log units) above the measured number; measured number outside the range, below it.
By their numbers in this assay, from the lowest: compound 3; then compounds 1 and 2 (each within the scatter of the next).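

In this assay, the aryl group on a double-bonded chain carbon bound to a double-bonded chain carbon can move the number beyond the scatter, which the fluoro step alone did not show: 4-methoxyphenyl in place of 2-fluorophenyl gives (a 7.8-fold lower number from compound 2 to compound 3 (0.89 log units; beyond the scatter)). The other new step reads in a similar way (a 6.7-fold lower number from compound 1 to compound 3 (0.82 log units; beyond the scatter)), so compound 3 separates from both compound 1 and compound 2, while those two remain together. Nothing available on these compounds accounts for the size of either step.

On these data alone, whether the lower number belongs to the methoxy group itself stays open, since a hydroxy group, an ethoxy group or an amine on the same aryl ring would be needed to separate that group from other replacements of hydrogen. Also open, as far as these compounds go, is whether the separation of compound 3 holds beyond a single read-out, as all three numbers come from this assay alone.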